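The source may hold more compounds than are shown below. What is called first, only, known or untested is meant among the compounds shown, and "the series" means these compounds.

Series values in a functional assay on MCF7 cells (Homo sapiens) for antiproliferative activity, read by CellTiter-Glo, with a stated time of 5 days; on this read-out lower numbers stand for stronger inhibition and higher numbers for weaker inhibition:
- Compound 1 `CC/C(=C(/c1ccc(/C=C/C(=O)O)cc1)c1ccc2scnc2c1)c1ccccc1`: 90 nM
- Compound 2 `CC/C(=C(/c1ccc(/C=C/C(=O)O)cc1)c1ccc(N2CCN(C)CC2)cc1)c1ccccc1`: 220 nM
- Compound 3 `O=C(O)/C=C/c1ccc(/C(=C(\c2ccccc2)C2CCC2)c2ccc3scnc3c2)cc1`: 16 nM

Compound 3 has the lowest number of the three. Next comes compound 4 `O=C(O)/C=C/c1ccc(/C(=C(\c2ccc(F)cc2Cl)C2CCC2)c2ccc3scnc3c2)cc1`, where 2-chloro-4-fluorophenyl takes the place of phenyl: 2-chloro-4-fluorophenyl in place of phenyl on a double-bonded chain carbon bound to a double-bonded chain carbon and a saturated ring carbon. Among the compounds with values here, the one measured step, a 5.6-fold lower number from compound 1 to compound 3 (0.75 log units; beyond the scatter), is cyclobutyl in place of ethyl at another place, so it bears only indirectly. Within the data shown here, no measured step covers a change on this phenyl. In this assay a small move toward lower numbers is expected, smaller than that modest step and close to the scatter. The expected step is a 1.8-fold lower number from compound 3 to compound 4 (0.25 log units; within the scatter). The estimate for compound 4 is 9 nM, with an expected range of 2.5 nM to 32 nM.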

Compound 4, half-maximal inhibitory concentration: 3 nM
Compound 4: middle estimate off by 3.0-fold (0.48 log units), on the high side; measured number inside the range.
By their numbers in this assay, from the lowest: compound 4; then compound 3; then compound 1; then compound 2.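

In this assay, 2-chloro-4-fluorophenyl in place of phenyl gives a 5.3-fold lower number from compound 3 to compound 4 (0.73 log units; beyond the scatter), the first measured sign that this position responds to a change on its ring. This puts compound 4 at the lowest number in the series, with the cyclobutyl of compound 3 kept. Nothing at hand accounts for the size of this step.

The compounds shown leave open how much of the step belongs to the chlorine and how much to the fluorine. Going by these compounds, whether methoxy on this ring would give a comparable step also remains open.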